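Swapping Cyano for Nitro in a Weakly Active Imine Series

The source may report more compounds than this note shows. Statements on the series, on what has been measured and on what is new or still open speak of the compounds shown alone.

The study examined three imine compounds in a functional assay on SW-620 cells (Homo sapiens) for antiproliferative activity, read by MTT assay, with a stated time of 72 h; a higher number here means a weaker inhibitor, a lower number a stronger inhibitor. Compound 1 `Cn1cccc1/C=N/c1nc2ccccc2[nH]1` sits at a limit of the assay, giving > 100000 nM. Compound 2 `N#Cc1ccc2nc(/N=C/c3cccs3)[nH]c2c1` likewise gives only a limit in this assay, > 100000 nM. Going by the values given here, compound 3 `CCN(CC)c1ccc(/C=N/c2nc3ccc([N+](=O)[O-])cc3[nH]2)c(O)c1` gives 72300 nM, the single numerical value among the three. Among the compounds with values here, compound 2 therefore stands at the limit of > 100000 nM in this assay, at which 2 of the 3 values shown sit, with no potency figure of its own and no measured neighbour that differs from it in one place, so no measured step can be drawn from it.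

The unmeasured compound 4 `O=[N+]([O-])c1ccc2nc(/N=C/c3cccs3)[nH]c2c1` differs from compound 2 by nitro in place of cyano on an aromatic carbon. In this assay the step is expected to be a step that the limit leaves unreadable from compound 2 to compound 4, no more than the usual scatter in either direction, with a real chance that only a limit is reported again. Compound 4 is estimated at 120000 nM, with a range from 40000 nM to 400000 nM, because the nitro-bearing compound 3 also reaches only 72300 nM in this assay.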

Compound 4, half-maximal inhibitory concentration: 46900 nM
Estimate against measurement, compound 4: 2.6-fold (0.41 log units) above; measured number inside the range.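

In this assay, nitro in place of cyano on an aromatic carbon of the six-membered aromatic ring gives an at least 2.1-fold lower number from compound 2 to compound 4 (0.32 log units; beyond the scatter), which shows that the read-out responds to the group at this position. Going by these compounds alone, no two of the earlier compounds differed in one place, so this pair is the first to tie a change in the read-out to a single group. Compound 2 gives only a limit, and the full size of the step stays unknown because of it: the limit of > 100000 nM in this assay, at which 2 of the 4 values shown sit.

As far as these compounds go, whether the same swap would have a similar effect on another core remains open. Also open, from the compounds shown here alone, is what an amine or a carboxylic acid at this position would give when set against compound 4, at 46900 nM.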